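This account rests on a few compounds, and the source may have more. Where it says the series, first, only, none or still open, it means among the compounds named here.

Compound 1, `CCCCc1c(C)c(OC)c2ccccc2c1OC(C)=O`: 200 nM
Compound 2, `CCCCc1cc(OC)c2ccccc2c1OC(C)=O`: 440 nM
Compound 3, `CCCCc1cc(OC)c2c(C)cc(C)c(C)c2c1OC(C)=O`: 11900 nM

All three were tested in a functional assay for inhibition, with Rattus norvegicus as the target; on this read-out lower numbers stand for stronger inhibition and higher numbers for weaker inhibition. Compound 2 and compound 1 share a core and differ in one place: methyl in place of hydrogen on an aromatic carbon. This single change gave a 2.2-fold lower number from compound 2 to compound 1 (0.34 log units; beyond the scatter), so the added methyl went along with a somewhat stronger inhibition.

Compound 3 stands apart. Its core carries three methyl groups that compound 2 lacks, and the difference between the two cores is not broken down here; what the numbers show is that compound 3 gives the highest value of the three in this assay, far above compound 2 and further still above compound 1.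

Compound 4, `CCCCc1cc(OC)c2c(C)c(C)c(C)c(C)c2c1OC(C)=O`, has not yet been measured. It differs from compound 3 in one place: methyl in place of hydrogen on an aromatic carbon. Among the measured compounds shown here, this is the same kind of change as the one from compound 2 to compound 1, but the surroundings are not the same. In compound 2 the new methyl sits ortho to a butyl group and ortho to a methoxy group, and meta to an acetoxy group; in compound 3 it sits ortho to two methyl groups and meta to a methyl group.

For the measured compounds named here, with only one earlier instance of this kind of change, and that one in a different setting, the expectation for compound 4 is a step of about a 1.0-fold higher number from compound 3 to compound 4 (0.00 log units; within the scatter) from compound 3, roughly flat. Compound 4 is therefore expected to give about 12000 nM in this assay, most likely between 4000 nM and 40000 nM.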

Compound 4, half-maximal inhibitory concentration: 44100 nM
Compound 4: the middle estimate sits 3.7-fold (0.57 log units) below what was measured, and the stated range ends below it.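

In this assay the swap of hydrogen for methyl on an aromatic carbon gave a 3.7-fold higher number from compound 3 to compound 4 (0.57 log units; beyond the scatter) and so went along with weaker inhibition on this core, whereas the same kind of change went along with stronger inhibition on the core of compound 2. The two cases run in opposite directions, which shows that the effect of this change did not carry over from one core to the other in this series: the same change on two cores in this assay, a 2.2-fold lower number (0.34 log units; beyond the scatter) from compound 2 to compound 1 and a 3.7-fold higher number (0.57 log units; beyond the scatter) from compound 3 to compound 4, 8.2-fold (0.91 log units) apart, beyond the scatter of two such steps

These two cases do not tell which of the differences between the cores decides the direction, and two pairs are too few to predict the outcome on any further core.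

All the compounds shown keep the butyl chain, the methoxy group and the acetoxy group, so it remains open how a longer chain in place of butyl, or a hydroxyl group in place of acetoxy, would act on either core. On these data alone, it is also open whether a group other than methyl on the same aromatic carbon, such as chlorine or an amine, would show the same split between the two cores.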